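A few compounds are considered here, and "the series" means these few. Any claim that something is new, unique, unknown or untested is made for them only; others in the source may bear on it.

Measured compounds in a physicochemical assay for lipophilicity, read by HPLC, measured as octanol-water partition; a lower number here means a more polar compound, a higher number a more lipophilic compound:
Compound 1 `O=C1O[C@@H](CN2CCC(O)CC2)CN1c1ccc(-n2cc(-c3ccccn3)cn2)c(F)c1`: compound 1 gives 1.63.
Compound 2 `CS(=O)(=O)NC[C@H]1CN(c2ccc(-n3cc(-c4ccccn4)cn3)c(F)c2)C(=O)O1`: compound 2 gives 1.38.
Compound 3 `NC(=O)[C@H]1CN(c2ccc(-n3cc(-c4ccccn4)cn3)c(F)c2)C(=O)O1`: compound 3 gives 1.59.

Compound 1 holds the highest of the three numbers in this assay, yet all three sit within the scatter of one another: the step of a number 0.04 log units lower from compound 1 to compound 3 (within the scatter) and the step of a number 0.25 log units lower from compound 1 to compound 2 (within the scatter) are both inside the usual spread, as is the step of a number 0.21 log units higher from compound 2 to compound 3 (within the scatter). Compound 4 `CNC(=O)[C@H]1CN(c2ccc(-n3cc(-c4ccccn4)cn3)c(F)c2)C(=O)O1` is not yet measured. It differs from compound 1 in one place: methylcarbamoyl in place of (4-hydroxypiperidin-1-yl)methyl on a saturated ring carbon. Among the measured compounds shown here, the step that bears most directly on this is the one from compound 1 to compound 3, where carbamoyl took the place of the same leaving group at the same saturated ring carbon and the number barely moved. Methylcarbamoyl is the entering group here instead of carbamoyl, so only a small shift, if any, beyond the scatter is expected. For compound 4 the estimate in this assay is 1.85, with a range from 1.5 to 2.2, which amounts to an expected step of a number 0.22 log units higher from compound 1 to compound 4 (within the scatter).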

Compound 4, partition coefficient: 1.39
Beside the measured number, compound 4's estimate is 0.46 log units above it; measured number outside the range, below it.
By their numbers in this assay, from the lowest: compounds 2, 4, 3 and 1 (each within the scatter of the next).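

In this assay, among the compounds shown here, methylcarbamoyl in place of (4-hydroxypiperidin-1-yl)methyl on the saturated ring carbon gives a number 0.24 log units lower from compound 1 to compound 4 (within the scatter) as its step, and methyl in place of hydrogen on the amide-type nitrogen gives a number 0.20 log units lower from compound 3 to compound 4 (within the scatter) as its step, the first reading at this nitrogen. Methylcarbamoyl in place of (methanesulfonamido)methyl gives a number 0.01 log units higher from compound 2 to compound 4 (within the scatter) as its step, so with compound 4 added, no step among the four groups at this ring carbon leaves the scatter, whether the group carries a ring or not. No measurement on hand accounts for the size of these steps. As far as these compounds go, whether a carboxylic acid or a primary amine on this ring carbon would step beyond the scatter stays open. So does the reading for an ethyl or longer chain on the amide-type nitrogen.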